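A few compounds are considered here, and "the series" means these few. Any claim that something is new, unique, unknown or untested is made for them only; others in the source may bear on it.

In a functional assay on SH-SY5Y cells (Homo sapiens) for cytotoxicity, read by MTT assay, with a stated time of 48 h (a lower number here means a stronger inhibitor, a higher number a weaker inhibitor), two compounds that share one core have been measured so far. Compound 1 `COc1ccc2c(c1)nc(/C=C/C(=O)/C=C/c1ccc(O)c(OC)c1)n2C` gives 4800 nM, and compound 2 `COc1cc(/C=C/C(=O)/C=C/c2nc3cc([N+](=O)[O-])ccc3n2C)ccc1O` gives 4600 nM. These two values lie within the scatter of each other, so compound 2 stands level with compound 1 on the numbers available.

The next compound, compound 3 `COc1cc(/C=C/C(=O)/C=C/c2nc3cc(O)ccc3n2C)ccc1O`, keeps the rest of compound 2 and alters one group: hydroxy in place of nitro on an aromatic carbon, (hydroxy in place of nitro on an aromatic carbon). Among the compounds with values here, the one measured step that bears on this is a 1.0-fold lower number from compound 1 to compound 2 (0.02 log units; within the scatter), which put nitro in place of methoxy on that same aromatic carbon. On that step alone, no change beyond the scatter is expected in this assay. Hydroxy itself has not yet been tested at this place, and a single step is thin evidence, so the range is kept wide. The expected change is a 1.0-fold higher number from compound 2 to compound 3 (0.01 log units; within the scatter). For compound 3 the estimated value is 4700 nM, with an expected range from 1900 nM to 11000 nM.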

Compound 3, half-maximal inhibitory concentration: 4800 nM
Compound 3: middle estimate off by 1.0-fold (0.01 log units), on the low side; the range from low to high includes it.
By their numbers in this assay, from the lowest: compounds 2, 1 and 3 (each within the scatter of the next).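

In this assay, within the data shown here, the aromatic carbon of the shared core has now carried three groups (methoxy, nitro and hydroxy), and the numbers so far do not separate them. Putting hydroxy in place of nitro gives a 1.0-fold higher number from compound 2 to compound 3 (0.02 log units; within the scatter), even though this exchange replaces a larger group with a single oxygen and brings in a hydrogen-bond donor where nitro has none. The comparison with compound 1 adds a smaller change at the same place: hydrogen in place of methyl on the oxygen gives no change at the digits printed from compound 1 to compound 3 (within the scatter), so in this assay the free hydroxy and the methoxy group cannot be told apart, which the earlier pair could not show.

Still open, going by these compounds, is whether any group on this carbon can move the number beyond the scatter, for example an amine, a carboxylic acid or a longer chain on the oxygen. No measurement is available that would explain why these three groups read alike, and the data here give no reason for it.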